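A few compounds are considered here, and "the series" means these few. Any claim that something is new, unique, unknown or untested is made for them only; others in the source may bear on it.

Measured in a functional assay on KM12 cells (Homo sapiens) for antiproliferative activity; on this read-out higher numbers stand for weaker inhibition of growth and lower numbers for stronger inhibition of growth:
- Compound 1 `COc1ccc(-c2nc3cc(F)ccc3s2)cc1`: 24600 nM
- Compound 2 `COc1ccc(-c2nc3cc(F)ccc3s2)cc1Cl`: 7050 nM

Of these two numbers, the lower belongs to compound 2 at 7050 nM, which makes it the stronger inhibitor of growth so far. The next structure, compound 3 `COc1ccc(-c2nc3cc(F)ccc3s2)cc1Br`, alters compound 2 at a single place: bromo in place of chloro on an aromatic carbon. The swap is bromo in place of chloro on an aromatic carbon, ortho to a methoxy group. For the measured compounds named here, only one measured step bears on this: a 3.5-fold lower number from compound 1 to compound 2 (0.54 log units; beyond the scatter), a modest change that came with chloro in place of hydrogen. Going by the values given here, no measured compound carries bromo, so the data offer no direct test. That earlier step put a halogen where none stood, whereas this one exchanges one halogen for another, so no step beyond the scatter is expected in this assay. The expected change is a 1.2-fold lower number from compound 2 to compound 3 (0.07 log units; within the scatter). For compound 3 the estimated value is 6000 nM, with an expected range of 2500 nM to 13000 nM.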

Compound 3, concentration for 50% growth inhibition: 6700 nM
Beside the measured number, compound 3's estimate is 1.1-fold (0.05 log units) below it; measured number inside the range.
By their numbers in this assay, from the lowest: compounds 3 and 2 (each within the scatter of the next); then compound 1.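

Bromo in place of chloro on this aromatic carbon gives a 1.1-fold lower number from compound 2 to compound 3 (0.02 log units; within the scatter) in this assay and so, on this read-out, the two halogens cannot be told apart at this position. Bromo in place of hydrogen gives a 3.7-fold lower number from compound 1 to compound 3 (0.56 log units; beyond the scatter) and thereby shows that the drop seen with chloro is not confined to that one halogen: compound 2 and compound 3 both stand clear of compound 1, which carries hydrogen here. Nothing measured here explains why the two halogens match.

Still open, on these data alone, is whether a group that is not a halogen, such as an amine or a carboxylic acid, would give a similar number on this carbon. Also open, as far as these compounds go, is whether iodo would match chloro and bromo, and whether the step would hold with hydroxyl in place of the methoxy group.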